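Oxadiazole in place of carbamate on a sulfonamide series

The compounds below may be only part of what the source reports. "The series", "measured", "known", "first", "only" and "open" are said of these compounds alone.

Of the compounds shown here, three sharing one core have been measured in a functional assay on MIA PaCa-2 cells (Homo sapiens) for inhibition, read by MTT assay, with a stated time of 3 days; a higher number here means a weaker inhibitor, a lower number a stronger inhibitor. Compound 1, `CCOC(=O)[C@@H]1CCCN(S(=O)(=O)c2ccc(S(=N)(=O)N(CC)CC)cc2)C1`, gives 900 nM in this assay. Among the compounds with values here, compound 3, `CCOC(=O)[C@@H]1CCCN(S(=O)(=O)c2ccc(C(=O)N(CC)CC)cc2)C1`, gives 100 nM, and the single one-place step between measured compounds is a 9.0-fold lower number from compound 1 to compound 3 (0.95 log units; beyond the scatter), a change on an aromatic carbon of the core. Compound 2, `CCN(CC)S(=O)(=O)c1ccc(S(=O)(=O)N2CCC[C@@H](C(=O)N3CCN(C(=O)OC(C)(C)C)CC3)C2)cc1`, gives 10 nM, the lowest number of the three, beyond the scatter from both compound 3 and compound 1, so compound 2 counts as the strongest inhibitor measured so far.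

Compound 4, `CCN(CC)S(=O)(=O)c1ccc(S(=O)(=O)N2CCC[C@@H](C(=O)N3CCN(c4nc(C(C)C)no4)CC3)C2)cc1`, differs from compound 2 in one place: 3-isopropyl-1,2,4-oxadiazol-5-yl in place of tert-butoxycarbonyl on an amine nitrogen in a ring. Within the data shown here, none of the measured steps bears on this change. Among the measured compounds shown here, the only step known, from compound 1 to compound 3, concerns a group on an aromatic carbon of the core, not the amine nitrogen in the ring where compound 4 changes, and its size cannot be carried over. For the measured compounds named here, with no step at this position to draw on, compound 4 is expected to stay close to compound 2, with no step beyond the scatter in either direction. Compound 4 is therefore estimated at 12 nM, within a range from 3 nM to 50 nM. The expected step is a 1.2-fold higher number from compound 2 to compound 4 (0.08 log units; within the scatter).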

Compound 4, half-maximal inhibitory concentration: 30 nM
Compound 4: the middle estimate sits 2.5-fold (0.40 log units) below what was measured, within the range that was stated.
By their numbers in this assay, from the lowest: compound 2; then compound 4; then compound 3; then compound 1.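

Within the data shown here, at the amine nitrogen in the six-membered ring, which no earlier step had touched, 3-isopropyl-1,2,4-oxadiazol-5-yl in place of tert-butoxycarbonyl gives a 3.0-fold higher number from compound 2 to compound 4 (0.48 log units; beyond the scatter) in this assay, so the group carried here does change the reading. The step is modest, which shows that a five-membered aromatic ring can stand on this nitrogen in place of a group with no ring at a measurable but limited cost, and compound 2 remains the strongest inhibitor of the series shown. No measurement at hand accounts for this step.

With one step at this position, the compounds shown cannot separate the contribution of the oxadiazole ring from that of its isopropyl group, which a methyl or cyclopropyl group on the same ring would help to resolve. They also leave open how this nitrogen behaves with an acetyl group, a benzyl group or no substituent at all, and whether the step would keep its size with the other groups seen on the aromatic carbon of the core.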